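The source may hold more compounds than are shown below. What is called first, only, known or untested is meant among the compounds shown, and "the series" means these compounds.

Compound 1 `CCN(C)CC#CCCC1SCCCS1`: in a functional assay for antagonist activity, with Cavia porcellus as the target (a higher number here means a weaker inhibitor, a lower number a stronger inhibitor), compound 1 gives > 10000000 nM, which is a limit of the assay rather than a number.
Compound 2 `CN(C)CC#CCCC1SCCCS1`: in this assay compound 2 gives > 10000000 nM, again a limit.
Compound 3 `CN(C)CC#CCCC1(C(O)(c2ccccc2)c2ccccc2)SCCCS1`: in this assay compound 3 gives 1810 nM.

Compound 1 differs from compound 2 by methyl in place of hydrogen on a saturated chain carbon bound to an amine nitrogen. The step that the two limits leave unreadable from compound 2 to compound 1 has no readable size because of the limit of > 10000000 nM in this assay, at which 2 of the 3 values shown sit. The core of compound 3 differs from that of compound 2 in more than one place; the difference between the two cores is not broken down here.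

Compound 4 `CCN(C)CC#CCCC1(C(O)(c2ccccc2)c2ccccc2)SCCCS1` has not yet been measured. It differs from compound 3 by methyl in place of hydrogen on a saturated chain carbon bound to an amine nitrogen, the same change at the same place. In this assay only a small step is expected, a 1.2-fold higher number from compound 3 to compound 4 (0.08 log units; within the scatter), since the earlier pair gives no readable size in a step that the two limits leave unreadable from compound 2 to compound 1. Compound 4 is thus expected to give about 2200 nM, roughly between 700 nM and 7000 nM.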

Compound 4, antagonist equilibrium constant: 1230 nM
For compound 4 the middle estimate is 1.8-fold (0.25 log units) above the measured one; low and high end bracket the measured number.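

In this assay, methyl in place of hydrogen on a saturated chain carbon bound to an amine nitrogen, which turns dimethylamino into ethyl(methyl)amino, gives a 1.5-fold lower number from compound 3 to compound 4 (0.17 log units; within the scatter), so on this core the two values cannot be told apart. The same swap on the core of compound 2 gives compound 1, and that step cannot be read, because both compounds stand at a limit of the assay rather than at a number: the limit of > 10000000 nM in this assay, at which 2 of the 4 values shown sit. The series therefore shows the swap on one core only and does not show that its size carries from one core to another.

As far as these compounds go, it remains open how diethylamino or a longer chain, such as propyl, in place of the ethyl of ethyl(methyl)amino would read on the core of compound 3. From the compounds shown here alone, a readable comparison on a second core also remains open.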